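The compounds below may be only part of what the source reports. "The series", "measured", "known", "first", "only" and "open" are said of these compounds alone.

Compound 1 `Cc1nc(S(C)(=O)=O)ccc1Oc1ncnc(OC2CCN(C(=O)OC(C)C)CC2)c1F`, compound 2 `Cc1nc(S(C)(=O)=O)ccc1Oc1ncnc(OC2CCN(C(=O)OC(C)F)CC2)c1F` and compound 3 `Cc1nc(S(C)(=O)=O)ccc1Oc1ncnc(OC2CCN(C(=O)C(F)(F)F)CC2)c1F` share a core and differ only in the group on the carbonyl carbon whose other neighbour is an amide-type nitrogen in a ring. In a functional assay on isolated protein for inhibition of Glucose-dependent insulinotropic receptor (Rattus norvegicus), read by HTRF and cAMP accumulation (on this read-out lower numbers stand for an effect already at smaller amounts and higher numbers for an effect only at larger amounts of compound), compound 1 gives 142 nM, compound 2 gives 315 nM and compound 3 gives 880 nM. The change methyl in place of fluoro on a saturated chain carbon bound to an oxygen next to a carbonyl group and a saturated chain carbon brought a 2.2-fold lower number from compound 2 to compound 1 (0.35 log units; beyond the scatter). The core of compound 3 differs from that of compound 2 by a group of 4 heavy atoms (1 carbon, 3 fluorine; no ring) in place of a group of 4 heavy atoms (2 carbon, 1 oxygen, 1 fluorine; no ring), on a carbonyl carbon, which brought a 2.8-fold higher number from compound 2 to compound 3 (0.45 log units; beyond the scatter), and a 6.2-fold higher number from compound 1 to compound 3 (0.79 log units; beyond the scatter) separates compound 1 from compound 3. Compound 4 `Cc1nc(S(C)(=O)=O)ccc1Oc1ncnc(OC2CCN(C(=O)C(C)(F)F)CC2)c1F` is not yet measured; it arises from compound 3 by methyl in place of fluoro on a saturated chain carbon bound to a carbonyl carbon and two fluorine atoms. For the measured compounds named here, this is the same kind of change as the one from compound 2 to compound 1, but the place differs: there the saturated chain carbon was bound to an oxygen next to a carbonyl group and a saturated chain carbon, here it is bound to a carbonyl carbon and two fluorine atoms. Going by the values given here, for compound 4 the step is estimated at a 2.0-fold lower number from compound 3 to compound 4 (0.29 log units; within the scatter), an expectation resting only on the single earlier example, a 2.2-fold lower number from compound 2 to compound 1 (0.35 log units; beyond the scatter). In this assay compound 4 is expected at 450 nM, estimated to fall between 200 nM and 1000 nM.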

Compound 4, half-maximal effective concentration: 239 nM
Beside the measured number, compound 4's estimate is 1.9-fold (0.27 log units) above it; the measured number falls inside the stated range.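

In this assay, methyl in place of fluoro gave a 3.7-fold lower number from compound 3 to compound 4 (0.57 log units; beyond the scatter), and the change ran the same way on both cores, with the two steps not told apart: the same change on two cores in this assay, a 2.2-fold lower number (0.35 log units; beyond the scatter) from compound 2 to compound 1 and a 3.7-fold lower number (0.57 log units; beyond the scatter) from compound 3 to compound 4, 1.7-fold (0.22 log units) apart, within the scatter of two such steps

For these two cores the change therefore carried over in direction and in approximate size, but two examples, at a saturated chain carbon bound to an oxygen and at one bound to a carbonyl carbon and two fluorine atoms, set no rule for the series. The other new steps, a 1.3-fold lower number from compound 2 to compound 4 (0.12 log units; within the scatter) and a 1.7-fold higher number from compound 1 to compound 4 (0.23 log units; within the scatter), both lie within the scatter and leave 1,1-difluoroethyl unranked against the 1-fluoroethoxy and isopropoxy groups.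

The compounds shown leave open whether methyl in place of fluoro would act alike on a longer chain or on a cyclopropyl group on the carbonyl carbon. They also leave open how an amine or a carboxylic acid on that carbon would read.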